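A few compounds are considered here, and "the series" means these few. Any claim that something is new, unique, unknown or untested is made for them only; others in the source may bear on it.

Three ureas sharing one core have been examined in an ADME assay on HEK293 cells (Homo sapiens) for cytotoxicity, with a stated time of 72 h; on this read-out lower numbers stand for an effect already at smaller amounts and higher numbers for an effect only at larger amounts of compound. Compound 1 `Cc1cc(NC(=O)Nc2ccc(C)c(Cl)c2)c2ccccc2n1` carries on one urea nitrogen a phenyl ring bearing a chlorine and a methyl group. In this assay compound 1 reaches only > 25000 nM, which is a limit of the assay and not a number. Compound 2 `Cc1cc(NC(=O)Nc2cc(F)ccc2F)c2ccccc2n1` carries a phenyl ring bearing two fluorines in the same place, and in this assay compound 2 gives a measured value of 12000 nM. Compound 3 `Cc1cc(NC(=O)Nc2ncccc2C)c2ccccc2n1` carries a 3-methylpyridin-2-yl group on that nitrogen. In this assay compound 3 stops at > 25000 nM, again a limit rather than a number. So compound 3 stands where most of this small set stands, because of the limit of > 25000 nM in this assay, at which 2 of the 3 values shown sit.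

Compound 4 `Cc1cc(NC(=O)Nc2ccc(F)cc2)c2ccccc2n1` has not been measured yet. It differs from compound 3 in one place: 4-fluorophenyl in place of 3-methylpyridin-2-yl on an amide-type nitrogen. Within the data shown here, no measured pair in the set differs in a single place, so the size of such a step cannot be read from the data; the one numeric value, from compound 2 with its two fluorines, lies not far from the limit. The step from compound 3 to compound 4 is therefore expected to be an at least 1.1-fold lower number from compound 3 to compound 4 (0.05 log units; that floor lies within the scatter), nothing beyond the usual scatter. Compound 4 is estimated at 22000 nM, within a range of 9000 nM to 50000 nM, and it may well again be reported only as a limit.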

Compound 4, half-maximal effective concentration: > 25000 nM
Compound 4 gave a limit, no number; the forecaster's own chance of this, stated with the estimate: 55%; middle value at least 1.1-fold (0.05 log units) from the limit.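

Compound 3 and compound 4 both stop at a limit of the assay rather than a number, and the step between them cannot be read in this assay: the limit of > 25000 nM in this assay, at which 3 of the 4 values shown sit. The compounds shown leave open how far a single change on the amide-type nitrogen moves the value in this assay.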